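Chloro addition on the trifluoromethyl-pyridyl analogue

The compounds below may be only part of what the source reports. "The series", "measured", "known", "first", "only" and "open" are said of these compounds alone.

Measured compounds:
Compound 1 `COc1cc(/C=C2\C(=O)Nc3ccccc32)ccc1OCCCN1CCN(c2ccccn2)CC1` in a functional assay on A549 cells (Homo sapiens) for cytotoxicity, read by MTT assay, with a stated time of 48 h (on this read-out higher numbers stand for weaker inhibition and lower numbers for stronger inhibition), gives > 20000 nM, a limit of the assay.
Compound 2 `COc1cc(/C=C2\C(=O)Nc3ccc(Cl)cc32)ccc1OCCCN1CCN(c2ccccn2)CC1` in this assay gives > 20000 nM, a limit of the assay.
Compound 3 `COc1cc(/C=C2\C(=O)Nc3ccccc32)ccc1OCCCN1CCN(c2ncccc2C(F)(F)F)CC1` in this assay gives > 20000 nM, a limit of the assay.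

Compound 3 thus stands only at a limit in this assay; no number is known for it. Compound 4 `COc1cc(/C=C2\C(=O)Nc3ccc(Cl)cc32)ccc1OCCCN1CCN(c2ncccc2C(F)(F)F)CC1` differs from compound 3 by chloro in place of hydrogen on an aromatic carbon. The measured steps that bear on this change are a step that the two limits leave unreadable from compound 1 to compound 2, the same chloro addition on the shared core without the trifluoromethyl, and a step that the two limits leave unreadable from compound 1 to compound 3. Both are unreadable because of the limit of > 20000 nM in this assay, at which 3 of the 3 values shown sit. With no readable step in hand, no direction beyond the scatter can be assigned, and the expectation is that compound 4 also stays at the limit. The expected step from compound 3 to compound 4 is a step that the limit leaves unreadable from compound 3 to compound 4. Compound 4 is estimated at 30000 nM, with a range from 12000 nM to 100000 nM.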

Compound 4, half-maximal inhibitory concentration: 9530 nM
Estimate against measurement, compound 4: 3.1-fold (0.50 log units) above; the whole stated range lies above it.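

In this assay, chloro and trifluoromethyl together bring the series off the limit: adding chloro gives an at least 2.0-fold lower number from compound 3 to compound 4 (0.32 log units; beyond the scatter), and adding trifluoromethyl gives an at least 2.0-fold lower number from compound 2 to compound 4 (0.32 log units; beyond the scatter). Compound 4 is the only compound shown with a measured number. The steps from compound 1 to the analogues carrying one of these groups cannot be read, so neither group alone is shown to change the read-out.

As far as these compounds go, the true size of both new steps stays open, with only minimum sizes available. From the compounds shown here alone, whether bromo or a nitrile could replace chloro on this aromatic carbon also stays open.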